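The source may hold more compounds than are shown below. What is called first, only, known or untested is meant among the compounds shown, and "the series" means these compounds.

In a functional assay on HT-29 cells (Homo sapiens) for antiproliferative activity, read by sulforhodamine B assay, with a stated time of 48 h (a higher number here means a weaker inhibitor, a lower number a stronger inhibitor), three compounds sharing one core have been measured. Compound 1 (`COc1ccccc1OS(=O)(=O)c1ccc(N2CCN(C)C2=O)cc1`) gives 26000 nM, the highest number of the three, which makes it the weakest inhibitor among them. Compound 2 (`CN1CCN(c2ccc(S(=O)(=O)Oc3cc(Cl)c(Cl)cc3Cl)cc2)C1=O`) gives 600 nM and compound 3 (`COc1cc(OS(=O)(=O)c2ccc(N3CCN(C)C3=O)cc2)cc(OC)c1OC`) gives 62 nM, and both lie beyond the scatter from compound 1.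

Compound 4 (`Cc1ccc(OS(=O)(=O)c2ccc(N3CCN(C)C3=O)cc2)cc1`) has not yet been measured. It has 4-methylphenyl in place of 2-methoxyphenyl on an oxygen, the rest of compound 1 being unchanged: 4-methylphenyl in place of 2-methoxyphenyl on an oxygen. Among the measured compounds shown here, no measured pair differs in one place only, so any forecast here stays loose. Compound 1 at 26000 nM sits at the top of the measured range, and compound 2 at 600 nM shows that another group at this place can give a much lower number, so a move toward stronger inhibition is expected. The estimated step is an 8.7-fold lower number from compound 1 to compound 4 (0.94 log units; beyond the scatter), beyond the scatter. Compound 4 is expected at 3000 nM, with an estimated range from 500 nM to 15000 nM.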

Compound 4, half-maximal inhibitory concentration: > 100000 nM
Compound 4 gave a limit, no number; the forecaster's own chance of this, stated with the estimate: 10%; at least 33-fold (1.52 log units) between middle value and limit.
By their numbers in this assay, from the lowest: compound 3; then compound 2; then compound 1. At a limit, above all of these: compound 4.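

In this assay, compound 4 gives a limit of the assay and not a number: the limit of > 100000 nM in this assay, at which 1 of the 4 values shown sits. Placing 4-methylphenyl instead of 2-methoxyphenyl on the oxygen bound to the sulfonyl sulfur gives an at least 3.8-fold higher number from compound 1 to compound 4 (0.58 log units; beyond the scatter), so the top of the measured range was not set by compound 1, and a change at this place can also raise the number. The group that leaves holds one hydrogen-bond acceptor and the one that enters holds none, but this single change cannot separate the loss of the methoxy group from the arrival of the methyl group or the altered placement on the ring.

Going by these compounds, it remains open how an unsubstituted phenyl ring would read at this place. The same holds for a phenyl ring carrying an amine or a carboxylic acid.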